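Methyl in place of hydrogen, compound 3 to compound 4

A few compounds are considered here, and "the series" means these few. Any claim that something is new, unique, unknown or untested is made for them only; others in the source may bear on it.

Compound 3 `Oc1nncc2cnc(Cc3ccccc3)n12` returns only a limit in a functional assay for inhibition, with Homo sapiens as the target; on this read-out higher numbers stand for weaker inhibition and lower numbers for stronger inhibition: compound 3 gives > 48000 nM, a limit and not a number. Compound 1 `CCCCCCCCCCCCCCCCCc1ncc2cnnc(S)n12` likewise gives the limit > 48000 nM in this assay. Compound 2 `CSc1nncc2c(C)nc(C(C)C)n12` gives the limit > 48000 nM in this assay. Within the data shown here, the whole measured set shares (the limit of > 48000 nM in this assay, at which 3 of the 3 values shown sit), so no step between measured compounds can be sized. Compound 4 `Cc1nc(Cc2ccccc2)n2c(O)nncc12` differs from compound 3 by methyl in place of hydrogen on an aromatic carbon. Among the measured compounds shown here, with no measured step to lean on, the expectation for this assay is no change beyond the scatter, and compound 4 is expected to return a limit again. The expected step that the limit leaves unreadable from compound 3 to compound 4 is thus near nil, with compound 4 estimated at 60000 nM in the range 20000 nM to 200000 nM.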

Compound 4, half-maximal inhibitory concentration: > 48000 nM
Compound 4 was reported as a limit; the forecaster's own chance of this, stated with the estimate: 85%; the middle value is on the limit's open side.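

No step can be read between compound 3 and compound 4, because both are limits in this assay: the limit of > 48000 nM in this assay, at which 4 of the 4 values shown sit.

The compounds shown leave open whether methyl in place of hydrogen changes inhibition, and what inhibition any of them has as a readable number.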